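A few compounds are considered here, and "the series" means these few. Any claim that something is new, unique, unknown or untested is made for them only; others in the source may bear on it.

Measured in a functional assay on HCT-116 cells (Homo sapiens) for antiproliferative activity, read by MTT assay, with a stated time of 48 h; on this read-out lower numbers stand for stronger inhibition and higher numbers for weaker inhibition:
Compound 1 `CCCCC(CCO)n1cnc2c(Cl)ncnc21` gives > 50000 nM, a limit.
Compound 2 `CCCCC(CCO)n1cnc2c(OC)ncnc21` gives > 50000 nM, a limit.
Compound 3 `CCCCC(CCO)n1cnc2cncnc21` gives > 50000 nM, a limit.

For the measured compounds named here, the series so far rests on (the limit of > 50000 nM in this assay, at which 3 of the 3 values shown sit). Compound 2 thus stands only at a limit, with no number to start from. Compound 4 `CCCCCC(CCO)n1cnc2c(OC)ncnc21` differs from it by methyl in place of hydrogen on a saturated chain carbon, five bonds along the chain from an aromatic nitrogen. The measured steps that touch compound 2, a step that the two limits leave unreadable from compound 1 to compound 2 and a step that the two limits leave unreadable from compound 2 to compound 3, lie on an aromatic carbon and give no size to carry over. The step expected in this assay is a number no higher from compound 2 to compound 4 (the limit leaves the size open), with nothing foreseen beyond the scatter. The estimate for compound 4 is 50000 nM, within 20000 nM to 100000 nM.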

Compound 4, half-maximal inhibitory concentration: > 50000 nM
Compound 4 ended at the assay's limit (the forecaster's own chance of this, stated with the estimate: 85%); the middle value lies on the limit itself.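

For the compounds shown here, compound 2 and compound 4 both stand only at a limit, so no step between them can be read. The compounds shown leave open whether any change to the shared core or chain gives a measurable value rather than a limit.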